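Changing the Ring on the Carbonyl Carbon

The source may report more compounds than this note shows. Statements on the series, on what has been measured and on what is new or still open speak of the compounds shown alone.

Of the compounds shown here, two with a shared core have been measured. Compound 1 `O=C(Nc1cc(-c2ccccc2)nn1-c1ccccc1)c1cnccn1` carries a pyrazin-2-yl group on the carbonyl carbon, and in an assay on CHO cells with metabotropic glutamate receptor 5 (Homo sapiens) as the target (a lower number here means that less compound is needed, a higher number that more compound is needed for the effect), compound 1 gives 200 nM. Compound 2 `O=C(Nc1cc(-c2ccccc2)nn1-c1ccccc1)c1ccc(Cl)cc1` carries a 4-chlorophenyl group in that place instead, and in this assay compound 2 gives 20 nM. For the measured compounds named here, the step of a 10-fold lower number from compound 1 to compound 2 (1.00 log units; beyond the scatter) is the only measured step so far, and it leaves compound 2 with the lowest number of the two, compound 1 being its only neighbour.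

Compound 3 `O=C(Nc1cc(-c2ccccc2)nn1-c1ccccc1)c1ccsc1` differs from compound 2 in one place: thiophen-3-yl in place of 4-chlorophenyl on a carbonyl carbon. Going by the values given here, only one measured step bears on this change, because a 10-fold lower number from compound 1 to compound 2 (1.00 log units; beyond the scatter) shows that exchanging the ring on the carbonyl carbon can move the number by a clear amount. Among the compounds with values here, no measured pair shows what thiophen-3-yl does in this place. Since the 4-chlorophenyl gave the lowest number seen, a modest rise, a 2.5-fold higher number from compound 2 to compound 3 (0.40 log units; beyond the scatter), is expected rather than a further fall. For compound 3 the estimate in this assay is 50 nM, with a likely range from 10 nM to 250 nM.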

Compound 3, half-maximal effective concentration: 1800 nM
Beside the measured number, compound 3's estimate is 36-fold (1.56 log units) below it; measured number above the stated range.
By their numbers in this assay, from the lowest: compound 2; then compound 1; then compound 3.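

In this assay, the ring on the carbonyl carbon turns out to matter far more than the first pair suggested: thiophen-3-yl in place of 4-chlorophenyl gives a 90-fold higher number from compound 2 to compound 3 (1.95 log units; beyond the scatter), a large step and the biggest seen so far. Thiophen-3-yl also compares poorly with pyrazin-2-yl, with a 9.0-fold higher number from compound 1 to compound 3 (0.95 log units; beyond the scatter), so a small aromatic ring in this place does not by itself keep the number low, and among these three rings only 4-chlorophenyl reaches the low end. No measured information is available that explains why these rings differ so much.

The step from 4-chlorophenyl to thiophen-3-yl swaps a six-membered ring of carbon only for a five-membered ring with a sulfur atom and also removes the chlorine, and the compounds shown cannot separate these changes. A plain phenyl ring would show what the chlorine contributes on its own, and thiophen-2-yl or a 4-methoxyphenyl group would show how far the number depends on the ring itself or on what it carries.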